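The source may hold more compounds than are shown below. What is called first, only, known or untested is meant among the compounds shown, and "the series" means these compounds.

In a functional assay on cells (Lymphocyte, Homo sapiens), read by a luciferase reporter and ATP content, with a stated time of 48 h, tested at 1 uM (a lower number here means a stronger effect, a higher number a weaker effect of the compound at the concentration tested), compound 1 `CCCCCCCCCCCCCCCCc1nc(N2CCC2)nc(OC2CCC2)c1O` gives 100%. Compound 2 `CCCCCCCCCCCCCCc1nc(OC2CCC2)nc(N2CCC2)c1O` gives 109% in this assay, a number that lies within the usual scatter of the value of compound 1, so the two compounds show no separable effect at this concentration. Compound 3 `CCCCCCCCCCCCCCCCc1nc(OC2CCC2)nc(N2CCC2)c1O` differs from compound 2 by ethyl in place of hydrogen on a saturated chain carbon, ten or more bonds along the chain from an aromatic carbon. Compound 1 carries a chain of the same length and its value sits with that of compound 2, so for compound 3 the step of a number 6 percentage points lower from compound 2 to compound 3 (within the scatter) is expected to be no larger than the scatter. Compound 3 is expected to give 103%, within 85% to 120%.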

Compound 3, a percentage reported as activity, at one concentration (the size of the read-out at that concentration, not a potency): 102%
Compound 3: the middle estimate sits 1 percentage points above what was measured; low and high end bracket the measured number.
By their numbers in this assay, from the lowest: compounds 1, 3 and 2 (each within the scatter of the next).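

In this assay, ethyl in place of hydrogen on a saturated chain carbon, ten or more bonds along the chain from an aromatic carbon, gives a step that can be read directly (a number 7 percentage points lower from compound 2 to compound 3 (within the scatter)). For the compounds shown here, this is the first comparison of compounds differing in one place, and at this far end of the chain the two compounds cannot be told apart at the concentration tested. Nothing measured here accounts for this result. Open, as far as these compounds go, is whether a much shorter chain would separate from these compounds. So is whether an amine or a carboxylic acid at this position would.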